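The source may hold more compounds than are shown below. What is called first, only, known or untested is meant among the compounds shown, and "the series" means these compounds.

Measured compounds:
- Compound 1 `COC(=O)c1ccc(O)c(NC(=O)CCOc2ccc(C(C)(C)CC(C)(C)C)cc2)c1`: 1540 nM
- Compound 2 `CC(C)(C)CC(C)(C)c1ccc(OCC(=O)N2CCN(Cc3ccc(C(F)(F)F)cc3)CC2)cc1`: 4740 nM
- Compound 3 `COC(=O)c1cccc(NC(=O)C(C)(C)Oc2ccc(C(C)(C)CC(C)(C)C)cc2)c1`: 1400 nM

In an assay for inhibition of malate dehydrogenase, cytoplasmic (Homo sapiens), with a stated time of 30 min (on this read-out lower numbers stand for stronger inhibition and higher numbers for weaker inhibition), compound 3 gives 1400 nM, which is indistinguishable from compound 1 at 1540 nM within the usual scatter, while compound 2 at 4740 nM stands beyond the scatter, at a weaker level. Compound 4 `COC(=O)c1ccc(O)c(NC(=O)C(C)(C)Oc2ccc(C(C)(C)CC(C)(C)C)cc2)c1` has not yet been measured. It differs from compound 3 by hydroxy in place of hydrogen on an aromatic carbon. Going by the values given here, compound 1 already carries this hydroxy, on a different linker, and its number sits with that of compound 3, so no measured pair points to a clear effect. The expected step of a 1.2-fold lower number from compound 3 to compound 4 (0.07 log units; within the scatter) is therefore small, with no direction claimed beyond the scatter. Compound 4 is estimated at 1200 nM, in a range from 450 nM to 3500 nM.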

Compound 4, half-maximal inhibitory concentration: 3000 nM
Compound 4: the middle estimate sits 2.5-fold (0.40 log units) below what was measured, and the stated range covers the measured number.
By their numbers in this assay, from the lowest: compounds 3, 1, 4 and 2 (each within the scatter of the next, the first and the last beyond it).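

In this assay, hydroxy in place of hydrogen on this aromatic carbon, ortho to a large group and para to a methoxycarbonyl group, gives a 2.1-fold higher number from compound 3 to compound 4 (0.33 log units; beyond the scatter). Going by these compounds alone, this is the first change at a single place in this set, and it shows that the position is not indifferent: the added hydroxy modestly weakens inhibition. No measured evidence shown here accounts for the shift. The compounds shown leave open whether a methoxy group or an amine on this carbon would move the number the same way. They also leave open whether the same hydroxy change would have this effect on a different linker.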